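The source may hold more compounds than are shown below. What is called first, only, known or untested is meant among the compounds shown, and "the series" means these compounds.

Compound 1 `CC(C)n1c(=O)n(C(=O)NCCN2CCN(C)CC2)c2ccccc21` is a small set member whose potency in a functional assay for antagonist activity at 5-hydroxytryptamine receptor 4 (Cavia porcellus) (a lower number here means a less potent compound, a higher number a more potent compound, by a factor of ten per unit of this negative logarithm), is known only as an assay limit: in this assay compound 1 gives < 6. Compound 1 thus sits at the limit of < 6 in this assay, at which 1 of the 2 values shown sits, and no firm number for it exists. Compound 2 `CCN1CCN(CCNC(=O)n2c(=O)n(C(C)C)c3ccccc32)CC1` carries one extra methyl on the ring amine chain, and in this assay compound 2 gives 6.62, a change of a number at least 0.62 log units higher from compound 1 to compound 2 (beyond the scatter). The compound now in question, compound 3 `CN1CCN(CCNC(=O)n2c(=O)[nH]c3ccccc32)CC1`, differs from compound 1 in a different place: hydrogen in place of isopropyl on an aromatic nitrogen. Going by the values given here, none of the measured steps touches this position, so the step from compound 1 to compound 2 offers no direct guide, and compound 1 itself gives only a ceiling. The expectation is therefore that compound 3 stays low, with an estimated step that the limit leaves unreadable from compound 1 to compound 3. Compound 3 is estimated in this assay at 5.4, within a range of 4.7 to 6.1.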

Compound 3, negative logarithm of the antagonist equilibrium constant: < 6
Compound 3 gave a limit, no number (the forecaster's own chance of this, stated with the estimate: 75%); the middle value is on the limit's open side.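

Going by these compounds alone, compound 1 and compound 3 both give an assay limit rather than a firm number, so no step between them can be read: the limit of < 6 in this assay, at which 2 of the 3 values shown sit. On these data alone, how far hydrogen in place of isopropyl on an aromatic nitrogen changes potency in this assay, if at all, stays open.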